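The compounds below may be only part of what the source reports. "The series", "measured", "known", "first", "only" and "open" are said of these compounds alone.

Of the compounds shown here, two from this series have been measured so far, and both sit at a boundary of the assay rather than at a number. Compound 1 `C=C1C[C@]23C[C@@]1(O)CC[C@H]2c1ccc(O)c(C)c1[C@@H]3Cn1cc(-c2ccc(C(F)(F)F)cc2)nn1` gives in a functional assay on SMMC-7721 cells (Homo sapiens) for cytotoxicity, read by MTT assay, with a stated time of 4 days (a higher number here means a weaker inhibitor, a lower number a stronger inhibitor), a value of > 20000 nM, which is a limit of the assay and not a measured figure. Compound 2 `C=C1C[C@]23C[C@@]1(O)CC[C@H]2c1ccc(OS(=O)(=O)c2ccc(C)cc2)c(C)c1[C@@H]3Cn1cc(-c2ccc(C)cc2)nn1` gives in this assay a value of > 20000 nM, again only a limit. Compound 2 therefore stands exactly where the other shown value stands, at the boundary described by the limit of > 20000 nM in this assay, at which 2 of the 2 values shown sit. Compound 3 `C=C1C[C@]23C[C@@]1(O)CC[C@H]2c1ccc(OS(=O)(=O)c2ccc(C)cc2)c(C)c1[C@@H]3Cn1cc(-c2ccc(C(F)(F)F)cc2)nn1` differs from compound 2 by trifluoromethyl in place of methyl on an aromatic carbon. That same group is already present in compound 1, which likewise sits at a limit in this assay. For the measured compounds named here, no step between measured compounds is available to size this change, so the expectation is no shift beyond the scatter, with a step that the limit leaves unreadable from compound 2 to compound 3 as the estimated step. Compound 3 is expected to give about 30000 nM, within 12000 nM to 80000 nM, and most likely to be reported again only as a limit.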

Compound 3, half-maximal inhibitory concentration: > 20000 nM
Compound 3 gave a limit, no number (the forecaster's own chance of this, stated with the estimate: 85%); the middle value does not contradict the limit.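

No step can be read from compound 2 to compound 3 or from compound 1 to compound 3, because all three results stop at one limit, not a number: the limit of > 20000 nM in this assay, at which 3 of the 3 values shown sit. The compounds shown leave open how strongly each acts in this assay and whether either change alters that.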